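This account rests on a few compounds, and the source may have more. Where it says the series, first, only, none or still open, it means among the compounds named here.

Within the data shown here, compound 1 `CCC(CC)c1ccc2c(NCCCNCc3cc(F)ccc3OC)ccnc2c1` is one of three compounds measured in an ADME assay for permeability, using PAMPA, with a stated time of 30 min, at pH 7.4 (on this read-out higher numbers stand for higher permeability and lower numbers for lower permeability), in which compound 1 gives 23 10^-6 cm/s. Its two neighbours sit at the same level: compound 2 `Fc1ccc(Cc2ccc3c(NCCCNCc4ccco4)ccnc3c2)cc1` gives 23 10^-6 cm/s and compound 3 `CCC(CC)c1ccc2c(NCCCNCc3ccco3)ccnc2c1` gives 23 10^-6 cm/s. The step of no change at the digits printed from compound 1 to compound 3 (within the scatter) and the step of no change at the digits printed from compound 2 to compound 3 (within the scatter) together show that neither exchange on the saturated chain carbon nor exchange on the aromatic carbon moved the read-out beyond the scatter, so compound 1 stands level with both, nearest to compound 2 and furthest from compound 3 only in the sense of structure, not of number.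

Compound 4 `COc1ccc(F)cc1CNCCCNc1ccnc2cc(Oc3ccc(Cl)cc3)ccc12` has not yet been measured. The change from compound 1 to compound 4 is 4-chlorophenoxy in place of pentan-3-yl on an aromatic carbon. Among the measured compounds shown here, of the measured steps, only the one on the aromatic carbon bears on this change, and it left the read-out unchanged within the scatter; no measured step introduces a group of the kind that enters here, so the comparison is indirect. The expected step is therefore a 1.2-fold lower number from compound 1 to compound 4 (0.06 log units; within the scatter), that is, no change beyond the scatter. On that basis compound 4 is estimated to give 20 10^-6 cm/s in this assay, with a range from 8 10^-6 cm/s to 45 10^-6 cm/s.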

Compound 4, apparent permeability: 317 10^-6 cm/s
Compound 4: the middle estimate sits 16-fold (1.20 log units) below what was measured, outside the stated range (above it).
By their numbers in this assay, from the lowest: compounds 1, 2 and 3 (each within the scatter of the next); then compound 4.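

In this assay, exchanging pentan-3-yl for 4-chlorophenoxy on this aromatic carbon gives a 14-fold higher number from compound 1 to compound 4 (1.14 log units; beyond the scatter), so the position is not indifferent to what it carries, even though the earlier exchange there, with 4-fluorobenzyl leaving and pentan-3-yl entering, gave no change at the digits printed from compound 2 to compound 3 (within the scatter). The new group differs from both of those substituents in what it brings to this place: it carries an oxygen and a chlorine, and it adds a six-membered aromatic ring of carbon only. Nothing measured on these compounds accounts for the size of the rise.

The compounds shown do not separate the parts of the entering group, so a plain phenoxy, a 4-chlorophenyl or a 4-chlorobenzyl at this carbon would be needed to tell whether the oxygen, the chlorine or the ring goes with the higher number. From the compounds shown here alone, the flat step at this carbon was read with furan-2-yl on the chain and the large one with 5-fluoro-2-methoxyphenyl, so it also remains open whether 4-chlorophenoxy would give a similar rise with furan-2-yl in that place.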